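Moving Fluoro on the Benzoyl Ring of Compound 1

This account rests on a few compounds, and the source may have more. Where it says the series, first, only, none or still open, it means among the compounds named here.

Compound 1 `O=C(Nc1cc(-c2ccccc2)nn1-c1ccccc1)c1ccccc1` is the parent of this small series. In an assay on isolated protein with metabotropic glutamate receptor 5 (Rattus norvegicus) as the target (on this read-out higher numbers stand for an effect only at larger amounts of compound and lower numbers for an effect already at smaller amounts), compound 1 gives 300 nM, the highest of the two numbers obtained; the nearest is compound 2 `O=C(Nc1cc(-c2ccccc2)nn1-c1ccccc1)c1cccc(F)c1`, which gives 65 nM. That change, fluoro in place of hydrogen on an aromatic carbon, produced a 4.6-fold lower number from compound 1 to compound 2 (0.66 log units; beyond the scatter). Compound 3 `O=C(Nc1cc(-c2ccccc2)nn1-c1ccccc1)c1ccccc1O` reached only the limit of > 10000 nM in this assay, so no number is known for it. Its step from the parent was an at least 33-fold higher number from compound 1 to compound 3 (1.52 log units; beyond the scatter), and the step from compound 2 was an at least 150-fold higher number from compound 2 to compound 3 (2.18 log units; beyond the scatter); these follow from the limit of > 10000 nM in this assay, at which 1 of the 3 values shown sits.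

Compound 4 `O=C(Nc1cc(-c2ccccc2)nn1-c1ccccc1)c1ccc(F)cc1` carries fluoro in place of hydrogen on an aromatic carbon, placed on an aromatic carbon of a six-membered aromatic ring of carbon only, para to a large group. Among the compounds with values here, the one step that bears on it is the fluoro step from compound 1 to compound 2, a modest one. A comparable or smaller gain is expected, so a 2.0-fold lower number from compound 1 to compound 4 (0.30 log units; within the scatter) is estimated, giving compound 4 an expected value of 150 nM within 60 nM to 450 nM.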

Compound 4, half-maximal effective concentration: 50 nM
Estimate against measurement, compound 4: 3.0-fold (0.48 log units) above; measured number below the stated range.
By their numbers in this assay, from the lowest: compounds 4 and 2 (each within the scatter of the next); then compound 1. At a limit, above all of these: compound 3.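

Compound 4 shows that the gain from fluoro on the benzoyl ring is not tied to the place it has in compound 2: para to a large group it also lowers the number (a 6.0-fold lower number from compound 1 to compound 4 (0.78 log units; beyond the scatter)). The two fluoro placements cannot be told apart in this assay, as the step between them lies within the scatter (a 1.3-fold lower number from compound 2 to compound 4 (0.11 log units; within the scatter)). Compound 3 remains at a limit and not a number, so its step to the new compound (an at least 200-fold lower number from compound 3 to compound 4 (2.30 log units; beyond the scatter)) is a bound, and it rests on this limit: (the limit of > 10000 nM in this assay, at which 1 of the 4 values shown sits).

Still open, as far as these compounds go, is whether chloro, methoxy or an amine in place of the fluoro of compound 4 would behave as fluoro does. Also open, from the compounds shown here alone, is whether hydroxy would keep the number low at that same place.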